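Retrying a methoxy step on a different core

The compounds below may be only part of what the source reports. "The series", "measured", "known", "first", "only" and "open" are said of these compounds alone.

Measured so far:
compound 1, `COc1ccccc1N1CCN(CCCC(=O)NC2CCCc3c(OC)cccc32)CC1`, 35 nM
compound 2, `COc1ccccc1N1CCN(CCCC(=O)NC2CCCc3ccccc32)CC1`, 92 nM
compound 3, `O=C(CCCCCN1CCN(c2nc3ccccc3o2)CC1)NC1CCCc2ccccc21`, 820 nM

All three were tested in an assay on HEK293 cells for displacement of a labelled ligand from 5-hydroxytryptamine receptor 7 (Rattus norvegicus); a higher number here means a weaker inhibitor, a lower number a stronger inhibitor. Compound 2 and compound 1 differ by one change, (methoxy in place of hydrogen on an aromatic carbon), and this gave a 2.6-fold lower number from compound 2 to compound 1 (0.42 log units; beyond the scatter). Compound 3 shares the amide-linked ring of compound 2, but how its core differs from that of compound 2 is not broken down here; in this assay compound 3 gives the highest number of the three.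

Compound 4, `COc1ccc2oc(N3CCN(CCCCCC(=O)NC4CCCc5ccccc54)CC3)nc2c1`, carries the same kind of change on the core of compound 3: methoxy in place of hydrogen on an aromatic carbon. Here the place is meta and para to a fused ring, whereas in compound 1 it is ortho and meta to a fused ring. The step from compound 3 to compound 4 is expected to be a 1.6-fold lower number from compound 3 to compound 4 (0.21 log units; within the scatter). It is taken somewhat smaller than the earlier step because a 2.6-fold lower number from compound 2 to compound 1 (0.42 log units; beyond the scatter) was seen on a different core and at a different placement. Compound 4 is therefore estimated at 500 nM, with a plausible span from 200 nM to 1500 nM.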

Compound 4, inhibition constant: 704 nM
The estimate for compound 4 lay 1.4-fold (0.15 log units) below the measured number; measured number inside the range.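

In this assay, methoxy in place of hydrogen on the core of compound 3 gives a 1.2-fold lower number from compound 3 to compound 4 (0.07 log units; within the scatter) and so cannot be told apart from no change at all. Set beside the earlier step, this result does not clearly differ from it: the same change on two cores in this assay, a 2.6-fold lower number (0.42 log units; beyond the scatter) from compound 2 to compound 1 and a 1.2-fold lower number (0.07 log units; within the scatter) from compound 3 to compound 4, 2.3-fold (0.35 log units) apart, within the scatter of two such steps. This does not show that the change carries over equally, or that its effect is lost, since two pairs on different cores, with the methoxy at different places, are too few to settle either.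

The compounds shown leave open whether a hydroxyl or a fluorine at the same place would give a step beyond the scatter. They also leave open how a longer chain would alter the methoxy step.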